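Replacing an Anilino Group with a Difluorophenoxy Group

The compounds below may be only part of what the source reports. "The series", "measured", "known", "first", "only" and "open" are said of these compounds alone.

Three compounds built on one shared core have been examined. In a functional assay on MDA-MB-231 cells (Homo sapiens) for antiproliferative activity (a lower number here means a stronger inhibitor of growth, a higher number a weaker inhibitor of growth), compound 1 `Cc1cc(-c2cnn3c(NCC4CCOCC4)nc(NC4CCCC4)nc23)ccc1NC(=O)C1CC1` stands at "not determined" (no result reported), so no number is available for it. Compound 2 `O=C(NC1CC1)c1ccc(-c2cnn3c(NCC4CCOCC4)nc(NC4CCCC4)nc23)cc1` gives 690 nM in this assay. Compound 3 `Cc1cc(-c2cnn3c(NCC4CCOCC4)nc(Nc4ccccc4)nc23)ccc1C(=O)NC1CC1` gives 1200 nM in this assay; of the two numbers available it is the higher one, yet the gap to compound 2 lies within the usual scatter of repeated measurements, so the two compounds cannot be ranked against each other on these data.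

Compound 4 `Cc1cc(-c2cnn3c(NCC4CCOCC4)nc(Oc4cccc(F)c4F)nc23)ccc1C(=O)NC1CC1` differs from compound 3 in a single place: 2,3-difluorophenoxy in place of anilino on an aromatic carbon. For the measured compounds named here, no measured pair of compounds covers this change, so nothing in the data anchors the size of the step. With compound 3 at 1200 nM as the only point of reference, the step from compound 3 to compound 4 is expected to be modest, leaning towards a somewhat higher number, a 1.7-fold higher number from compound 3 to compound 4 (0.22 log units; within the scatter). Compound 4 is therefore estimated at 2000 nM in this assay, within a broad range from 600 nM to 7000 nM.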

Compound 4, concentration for 50% growth inhibition: 12 nM
Compound 4: the middle estimate sits 170-fold (2.22 log units) above what was measured; the whole stated range lies above it.
By their numbers in this assay, from the lowest: compound 4; then compounds 2 and 3 (each within the scatter of the next).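

At this position, on an aromatic carbon between two ring nitrogen atoms, the number in this assay proves highly sensitive to the group attached: 2,3-difluorophenoxy in place of anilino gives a large change (a 100-fold lower number from compound 3 to compound 4 (2.00 log units; beyond the scatter)), beyond the scatter. The earlier compounds shown here gave no sign of this, as compound 2 and compound 3 differ in more than one place and their values lie within the scatter of each other. Nothing available bears on the cause of the step.

The change removes the hydrogen-bond donor of the anilino group and adds two fluorine atoms in a single step, so the compounds shown leave open which part of the change carries the effect. A plain phenoxy group or a 2,3-difluoroanilino group on this carbon would separate the two.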